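Swapping fluoro for methyl on a hydroxamic acid pair

The source may hold more compounds than are shown below. What is called first, only, known or untested is meant among the compounds shown, and "the series" means these compounds.

Compound 1 `Cc1cc(-c2ccc(F)cc2)nn1Cc1ccc(C(=O)NO)cc1` and compound 2 `Cc1cc(-c2ccc(F)cc2)n(Cc2ccc(C(=O)NO)cc2)n1` are built from the same atoms joined differently; the difference between the two cores is not broken down here. In a functional assay on HepG2 cells (Homo sapiens) for antiproliferative activity, read by MTT assay, with a stated time of 96 h (on this read-out higher numbers stand for weaker inhibition of growth and lower numbers for stronger inhibition of growth), compound 1 gives 30000 nM, while compound 2 gives 3630 nM. Compound 3 `Cc1ccc(-c2cc(C)nn2Cc2ccc(C(=O)NO)cc2)cc1` arises from compound 2 by methyl in place of fluoro on an aromatic carbon, and in this assay compound 3 gives 13300 nM, a change of a 3.7-fold higher number from compound 2 to compound 3 (0.56 log units; beyond the scatter). Compound 4 `Cc1ccc(-c2cc(C)n(Cc3ccc(C(=O)NO)cc3)n2)cc1` stands in the same relation to compound 1: the change is methyl in place of fluoro on an aromatic carbon, the same change at the same place, the only other instance of it among these compounds. The expected step is a 3.0-fold higher number from compound 1 to compound 4 (0.48 log units; beyond the scatter), weakening growth inhibition much as the measured pair did. That expectation rests on compound 1 at 30000 nM and on the measured step of a 3.7-fold higher number from compound 2 to compound 3 (0.56 log units; beyond the scatter). Since compound 1 already gives the highest number of the three measured, the reading for compound 4 may approach the edge of what the assay can report. Compound 4 is estimated at 90000 nM in this assay, with a plausible range from 35000 nM to 250000 nM.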

Compound 4, concentration for 50% growth inhibition: 21200 nM
Compound 4: the middle estimate sits 4.2-fold (0.63 log units) above what was measured; the whole stated range lies above it.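

Measured, the swap from 4-fluorophenyl to 4-methylphenyl does not repeat its earlier effect: in this assay the new step is a 1.4-fold lower number from compound 1 to compound 4 (0.15 log units; within the scatter), so the change makes no reliable difference on this core. Set beside the earlier step, the same change clearly behaves differently on the two cores: the same change on two cores in this assay, a 3.7-fold higher number (0.56 log units; beyond the scatter) from compound 2 to compound 3 and a 1.4-fold lower number (0.15 log units; within the scatter) from compound 1 to compound 4, 5.2-fold (0.71 log units) apart, beyond the scatter of two such steps. In this small set, a step measured on one core is therefore a poor guide to the step on the other, but two pairs do not show why the cores differ or how the change would behave on any further core.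

The compounds shown leave open how other groups on that aromatic carbon, such as an amine or a carboxylic acid, would behave on each of the two cores. They also leave open whether the two cores would still respond differently if a longer chain took the place of the methyl group there.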